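The compounds below may be only part of what the source reports. "The series", "measured", "known", "first", "only" and "open" are said of these compounds alone.

Of the compounds shown here, three have been measured in an assay on HEK293 cells for displacement of a labelled ligand from D(4) dopamine receptor (Homo sapiens), read by scintillation counting, with a stated time of 60 min; on this read-out lower numbers stand for stronger inhibition and higher numbers for weaker inhibition. Compound 1 `Cc1cccc(NC(=O)CN2CCN(c3ccc(Cl)cn3)CC2)c1` gives 95 nM, and compound 2 `Cc1ccc(C2CCN(CC(=O)Nc3cccc(C)c3)CC2)cc1` gives 110 nM, so the two sit within the usual scatter of each other. For the measured compounds named here, compound 3 `O=C(CN1CCN(c2ccc(Cl)cn2)CC1)Nc1cccnc1` gives 5000 nM, and the single step between measured compounds that differ in one place is a 53-fold higher number from compound 1 to compound 3 (1.72 log units; beyond the scatter), a change on the amide-type nitrogen. On the numbers shown, compound 2 stands second highest of the three, close to compound 1 and far from compound 3.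

Compound 4 `Cc1cccc(NC(=O)CN2CCC(c3ccc(Cl)cc3)CC2)c1` has not yet been measured in this assay. Going by the values given here, it differs from compound 2 by chloro in place of methyl on an aromatic carbon, a change on the aromatic carbon para to a large group, far from the amide-type nitrogen where the only measured step took place. Among the compounds with values here, no measured step therefore bears on this change, and the expectation is that the step from compound 2 to compound 4 is a 1.1-fold lower number from compound 2 to compound 4 (0.04 log units; within the scatter), a change not beyond the scatter. Compound 4 is accordingly estimated at 100 nM, within a range from 40 nM to 250 nM.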

Compound 4, inhibition constant: 115 nM
Estimate against measurement, compound 4: 1.2-fold (0.06 log units) below; low and high end bracket the measured number.
By their numbers in this assay, from the lowest: compounds 1, 2 and 4 (each within the scatter of the next); then compound 3.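

In this assay the step from 4-methylphenyl to 4-chlorophenyl is a 1.0-fold higher number from compound 2 to compound 4 (0.02 log units; within the scatter) and so the two groups cannot be told apart at this position, on an aromatic carbon para to a large group. For the compounds shown here, the only earlier step, a 53-fold higher number from compound 1 to compound 3 (1.72 log units; beyond the scatter) on the amide-type nitrogen, showed how much one replacement can matter at that site, and this result shows that a methyl-to-chloro replacement on this aromatic carbon has no such measurable effect. The data offered here give no explanation for why these two groups read alike.

Going by these compounds, whether an amine, a carboxylic acid or a longer chain such as propyl on this same aromatic carbon would also stay within the scatter remains open. Also open, on these data alone, is whether chloro and methyl would still read alike with pyridin-3-yl on the amide-type nitrogen.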